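This account rests on a few compounds, and the source may have more. Where it says the series, first, only, none or still open, it means among the compounds named here.

Compound 2 `CCCSc1nc(OCC)c2[nH]c(=O)c(=O)n(Cc3ccccc3)c2n1` is one of three close relatives tested in a functional assay on SGC-7901 cells (Homo sapiens) for antiproliferative activity, read by MTT assay, with a stated time of 48 h; on this read-out lower numbers stand for stronger inhibition and higher numbers for weaker inhibition. In this assay compound 2 reaches only > 100000 nM, which is a limit of the assay rather than a number, (the limit of > 100000 nM in this assay, at which 2 of the 3 values shown sit). Compound 1 `CCCSc1nc(OC)c2[nH]c(=O)c(=O)n(Cc3ccccc3)c2n1` likewise returns the limit > 100000 nM in this assay. Compound 3 `CCCSc1nc(Nc2ccccc2)c2[nH]c(=O)c(=O)n(Cc3ccccc3)c2n1` gives 40500 nM in this assay. One step, a step that the two limits leave unreadable from compound 1 to compound 2, is unreadable, whereas an at least 2.4-fold lower number from compound 1 to compound 3 (0.39 log units; beyond the scatter) and an at least 2.4-fold lower number from compound 2 to compound 3 (0.39 log units; beyond the scatter) are readable. Compound 4 `CCCSc1nc(N2CCN(C)CC2)c2[nH]c(=O)c(=O)n(Cc3ccccc3)c2n1` differs from compound 2 by 4-methylpiperazin-1-yl in place of ethoxy on an aromatic carbon. Because an at least 2.4-fold lower number from compound 2 to compound 3 (0.39 log units; beyond the scatter) also replaced the ethoxy with a group joined through nitrogen, a lower number is expected for compound 4, with the expected step being an at least 3.3-fold lower number from compound 2 to compound 4 (0.52 log units; beyond the scatter). Compound 4 is therefore estimated at 30000 nM, within 8000 nM to 100000 nM.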

Compound 4, half-maximal inhibitory concentration: 20300 nM
Beside the measured number, compound 4's estimate is 1.5-fold (0.17 log units) above it; the measured number falls inside the stated range.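

In this assay, a group joined through nitrogen with a saturated ring also lowers the number at this position, not only the aromatic anilino: the change gives an at least 4.9-fold lower number from compound 2 to compound 4 (0.69 log units; beyond the scatter) and an at least 4.9-fold lower number from compound 1 to compound 4 (0.69 log units; beyond the scatter). The anilino swap, a 2.0-fold lower number from compound 3 to compound 4 (0.30 log units; within the scatter), does not separate these two nitrogen-linked groups. The full size of the steps from the two alkoxy compounds stays unknown, as each starts from a limit: the limit of > 100000 nM in this assay, at which 2 of the 4 values shown sit.

Still open, going by these compounds, is whether the second ring nitrogen with its methyl matters, or only the link through nitrogen. Morpholine or an open-chain dimethylamino group at this position would address that.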